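A few compounds are considered here, and "the series" means these few. Any claim that something is new, unique, unknown or untested is made for them only; others in the source may bear on it.

Measured so far:
compound 1, `CCO/N=C/Nc1cc(Cl)cc(Cl)c1`: 3
compound 2, `C#CCc1c(Cl)cc(N/C=N/OC)cc1Cl`: 3.3

Both numbers come from a physicochemical assay for lipophilicity, measured as octanol-water partition; a higher number here means a more lipophilic compound, a lower number a more polar compound. Compound 2 stands at the higher of the two, but compound 1 lies so close that the gap between them falls within the usual scatter, and nothing separates them beyond that.

Compound 3, `C#CCc1c(Cl)cc(N/C=N/Oc2ccc(C)cc2)cc1Cl`, has not yet been measured in this assay. It differs from compound 2 in a single place: 4-methylphenyl in place of methyl on an oxygen. Among the compounds with values here, no step between two measured compounds matches this change, so there is no measured step to scale it against. Even so, the expected step in this assay from compound 2 to compound 3 is an increase, clearly beyond the scatter, of about a number 1.70 log units higher from compound 2 to compound 3 (beyond the scatter). Compound 3 is therefore estimated to give 5 in this assay, with a range from 4.3 to 5.7.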

Compound 3, partition coefficient: 4.8
Estimate against measurement, compound 3: 0.20 log units above, and the stated range covers the measured number.
By their numbers in this assay, from the lowest: compounds 1 and 2 (each within the scatter of the next); then compound 3.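

Replacing methyl with 4-methylphenyl on an oxygen whose other neighbour is the double-bonded nitrogen gives a large change in this assay, a number 1.50 log units higher from compound 2 to compound 3 (beyond the scatter), and it lies beyond the scatter. Within the data shown here, the earlier compounds offered no pair differing in one place, so this is the first sign that a change at this oxygen can clearly move the number. Nothing available explains the size of this step.

Among these compounds, with only one change read at this oxygen, it remains open how much of the step belongs to the ring and how much to the methyl on it; plain phenyl or a longer chain such as butyl in the same place would help separate the two. Going by these compounds, whether a group carrying an amine here would move the number in the same direction is also open.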